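This account rests on a few compounds, and the source may have more. Where it says the series, first, only, none or still open, it means among the compounds named here.

Measured so far:
- compound 1, `CCCc1cc(N2CCCC2)c2cc(NC(=O)/C=C/c3ccc(C(F)(F)F)cc3)ccc2n1`: 17 nM
- compound 2, `CCCc1cc(N)c2cc(NC(=O)/C=C/c3ccc(F)cc3)ccc2n1`: 130 nM
- compound 3, `Nc1cc(C2CCCCC2)nc2ccc(NC(=O)/C=C/c3ccc(C(F)(F)F)cc3)cc12`: 1.2 nM

All three were tested in an assay on isolated protein for displacement of a labelled ligand from melanin-concentrating hormone receptor 1 (Homo sapiens); on this read-out lower numbers stand for stronger inhibition and higher numbers for weaker inhibition. Compound 2 carries the highest number of the three: compound 1 sits clearly lower, and compound 3 lower still, both beyond the usual scatter. Since compound 2 differs from each of the others in more than one place at once, its standing can only be read from the values themselves, not from any single change.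

The next compound, compound 4, `CCCCc1ccc(/C=C/C(=O)Nc2ccc3nc(CCC)cc(N)c3c2)cc1`, differs from compound 2 in exactly one place: butyl in place of fluoro on an aromatic carbon. Within the data shown here, nothing among the measured compounds shows this exact exchange, so the direction of the step can only be guessed from the whole set, where the two compounds with a larger group on that ring (compound 1 and compound 3) give the lower numbers. On that basis compound 2 to compound 4 is expected to bring a moderate drop in this assay, of roughly a 3.3-fold lower number from compound 2 to compound 4 (0.51 log units; beyond the scatter), which would reach beyond the scatter. For compound 4 the estimate is 40 nM, with a plausible range from 10 nM to 150 nM.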

Compound 4, half-maximal inhibitory concentration: 45 nM
Beside the measured number, compound 4's estimate is 1.1-fold (0.05 log units) below it; the measured number falls inside the stated range.
By their numbers in this assay, from the lowest: compound 3; then compound 1; then compound 4; then compound 2.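

In this assay, replacing fluoro with butyl on an aromatic carbon, para to a large group, gives a 2.9-fold lower number from compound 2 to compound 4 (0.46 log units; beyond the scatter), a modest step. Among these compounds, this is the first change on this ring that can be read on its own, as the earlier compounds all differ from one another in more than one place, and it shows that this position accepts a chain of 4 carbon atoms in place of a single fluorine, with the number falling rather than rising even though neither group has any hydrogen-bond donors or acceptors. No measurement here explains why the number falls with this exchange.

A single step cannot show whether the size of the group, its shape or something else drives the difference, and a shorter chain such as ethyl, a longer one such as hexyl, or a methoxy or carboxylic acid at this place would help to separate these. The trifluoromethyl group of compound 1 and compound 3 also remains to be compared with butyl and fluoro on the core of compound 2, since both compounds differ from it elsewhere as well.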